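A few compounds are considered here, and "the series" means these few. Any claim that something is new, unique, unknown or untested is made for them only; others in the source may bear on it.

Working notes on the series. Compound 1 `COc1cc2c(Oc3ccc(NC(=O)c4nn(-c5ccccc5)c(=O)c5ccccc45)cc3F)ccnc2cc1OCCCN1CCCC1` is the reference point; in a functional assay on HT-29 cells (Homo sapiens) for cytotoxicity, read by MTT assay, with a stated time of 72 h (on this read-out lower numbers stand for stronger inhibition and higher numbers for weaker inhibition), compound 1 gives 980 nM. Compound 2 `COc1cc2c(Oc3ccc(NC(=O)c4nn(-c5ccccc5)c(=O)c5ccccc45)cc3F)ccnc2cc1OCCCN1CCCCC1` carries a piperidin-1-yl in place of the pyrrolidin-1-yl on the saturated chain, and in this assay compound 2 gives 1310 nM. Going by the values given here, the step of a 1.3-fold higher number from compound 1 to compound 2 (0.13 log units; within the scatter) is the only measured change in the set, and it leaves the two numbers within the scatter of each other, so compound 2 and compound 1 cannot be separated on these data.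

Compound 3 `COc1ccc(-n2nc(C(=O)Nc3ccc(Oc4ccnc5cc(OCCCN6CCCCC6)c(OC)cc45)c(F)c3)c3ccccc3c2=O)cc1` differs from compound 2 by methoxy in place of hydrogen on an aromatic carbon. Among the compounds with values here, the single measured step concerns the saturated chain and not the phenyl on the shared core, so no measured step bears directly on this change; the only guidance is that the one variation tried so far did not move this assay beyond the scatter. On that basis a step of a 1.0-fold lower number from compound 2 to compound 3 (0.00 log units; within the scatter) is expected, that is, no change beyond the scatter in either direction. For compound 3 the estimated value in this assay is 1300 nM, with a range from 600 nM to 2800 nM.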

Compound 3, half-maximal inhibitory concentration: 1450 nM
Compound 3: the middle estimate sits 1.1-fold (0.05 log units) below what was measured, and the stated range covers the measured number.
By their numbers in this assay, from the lowest: compounds 1, 2 and 3 (each within the scatter of the next).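

In this assay, going by these compounds alone, the step of a 1.1-fold higher number from compound 2 to compound 3 (0.04 log units; within the scatter) gives the first measured reading at the phenyl on the shared core, where the earlier pair spoke only to the saturated chain. Going from phenyl to 4-methoxyphenyl, with methoxy entering on an aromatic carbon para to a large group, leaves compound 3 inseparable from compound 2 on these data, so this single substitution gives no sign that adding these 2 heavy atoms at this position shifts the cytotoxicity read-out beyond the scatter. No supporting measurement is available to explain this outcome or to indicate how the compounds behave beyond this read-out.

The compounds shown leave open whether a carboxylic acid, a primary amine or a nitrile at this same para place would separate from hydrogen and methoxy, since one neutral substituent cannot define the tolerance of the position. They also leave open whether 4-methoxyphenyl would read the same when paired with the pyrrolidin-1-yl chain end of compound 1, or with a longer chain carrying the piperidin-1-yl group.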